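A few compounds are considered here, and "the series" means these few. Any claim that something is new, unique, unknown or untested is made for them only; others in the source may bear on it.

Working notes on the series. In a functional assay on MGC-803 cells (Homo sapiens) for antiproliferative activity (on this read-out higher numbers stand for weaker inhibition and lower numbers for stronger inhibition), compound 1 (`CCCc1n[nH]c(C(N)=O)c1NC(=O)/C=C/c1ccccc1`) gives 3440 nM and compound 2 (`CCCc1n[nH]c(C(N)=O)c1NC(=O)/C=C/c1cc(OC)c(OC)c(OC)c1`) gives 4240 nM on the same read-out. These two numbers lie within the usual scatter of each other, so compound 1 has no place of its own apart from compound 2 so far.

The next compound to read is compound 3 (`CCCc1n[nH]c(C(N)=O)c1NC(=O)/C=C/c1ccco1`), which keeps the shared core of compound 1 and carries furan-2-yl in place of phenyl on a double-bonded chain carbon bound to a double-bonded chain carbon. Going by the values given here, no measured pair shows this exchange, so the expectation rests on very little. Among the compounds with values here, the only guide is that compound 2 at 4240 nM and compound 1 at 3440 nM sit within the scatter of each other, and on that basis no step beyond the scatter is expected in this assay for this change. The expected step of a 1.0-fold higher number from compound 1 to compound 3 (0.01 log units; within the scatter) has no firm direction. For compound 3 the estimated value is 3500 nM with an expected range from 1500 nM to 8000 nM on this read-out.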

Compound 3, half-maximal inhibitory concentration: 3010 nM
Compound 3: middle estimate off by 1.2-fold (0.07 log units), on the high side, and the stated range covers the measured number.
By their numbers in this assay, from the lowest: compounds 3, 1 and 2 (each within the scatter of the next).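

In this assay, going by these compounds alone, the exchange of phenyl for furan-2-yl on a double-bonded chain carbon bound to a double-bonded chain carbon gives a 1.1-fold lower number from compound 1 to compound 3 (0.06 log units; within the scatter), the first step that can be read at this place. A five-membered aromatic ring with 1 hetero atom can therefore stand in for a six-membered aromatic ring of carbon only, and the hydrogen-bond acceptor that enters with it brings no step beyond the scatter on this read-out. Nothing on hand bears on why the two rings read alike.

The compounds shown leave open whether any group at this place can move the number beyond the scatter, since all of those seen so far are aromatic rings without a charge, and an amine such as 4-aminophenyl or a carboxylic acid such as 4-carboxyphenyl would test a different kind of group. Also open, as far as these compounds go, is how much the rest of the molecule contributes, for instance whether a longer chain in place of propyl on the shared core changes the reading.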